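Compound 3 to compound 4: fluoro to trifluoromethyl

The source may hold more compounds than are shown below. What is called first, only, known or untested is meant among the compounds shown, and "the series" means these compounds.

In a functional assay on Gurav cells (Homo sapiens) for inhibition, read by sulforhodamine B assay (a higher number here means a weaker inhibitor of growth, a lower number a stronger inhibitor of growth), compound 3 (`Cc1ccc2[nH]c(-c3ccc(-c4ccc(-c5ccc(F)cc5)cc4)cc3)nc2c1`) has the highest number of the three measured compounds, at 16500 nM. Compound 1 (`Cc1ccc2[nH]c(-c3ccc(-c4ccc(-c5cccc(Cl)c5)cc4)cc3)nc2c1`) gives 2120 nM, and compound 2 (`COc1ccc(-c2ccc(-c3ccc(-c4nc5cc(C)ccc5[nH]4)cc3)cc2)cc1OC`) gives 1310 nM.

Compound 4 (`Cc1ccc2[nH]c(-c3ccc(-c4ccc(-c5ccc(C(F)(F)F)cc5)cc4)cc3)nc2c1`) has trifluoromethyl in place of fluoro on an aromatic carbon, para to a large group: trifluoromethyl in place of fluoro on an aromatic carbon.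

Two measured steps end on the 4-fluorophenyl group of compound 3. The modest one is a 7.8-fold higher number from compound 1 to compound 3 (0.89 log units; beyond the scatter), and the large one is a 13-fold higher number from compound 2 to compound 3 (1.10 log units; beyond the scatter). By contrast, a 1.6-fold lower number from compound 1 to compound 2 (0.21 log units; within the scatter) stays within the scatter. Within the data shown here, both other aryl groups therefore give lower numbers than 4-fluorophenyl, but no measured compound carries trifluoromethyl, so these steps guide the direction better than the size. A fall smaller than either step is expected, though one within the scatter remains possible.

The expected step is a 3.3-fold lower number from compound 3 to compound 4 (0.52 log units; beyond the scatter). For compound 4, the estimated value is 5000 nM, with an expected range of 1500 nM to 17000 nM.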

Compound 4, concentration for 50% growth inhibition: 12000 nM
Compound 4: middle estimate off by 2.4-fold (0.38 log units), on the low side; the range from low to high includes it.
By their numbers in this assay, from the lowest: compounds 2 and 1 (each within the scatter of the next); then compounds 4 and 3 (each within the scatter of the next).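

In this assay, trifluoromethyl in place of fluoro on this aromatic carbon, para to a large group, gives a 1.4-fold lower number from compound 3 to compound 4 (0.14 log units; within the scatter) and stays within the scatter, even with 4 heavy atoms entering for 1 leaving. Among these compounds, the gaps to the other two aryl groups, until now seen only with 4-fluorophenyl, also appear with 4-(trifluoromethyl)phenyl: a 9.2-fold higher number from compound 2 to compound 4 (0.96 log units; beyond the scatter) and a 5.7-fold higher number from compound 1 to compound 4 (0.75 log units; beyond the scatter) set compound 4 apart from both. No measurement at hand explains this grouping of compound 3 and compound 4.

The compounds shown leave open whether the gap follows the place of the substituent on the outer ring or its identity, a question that 4-chlorophenyl or 3-fluorophenyl could separate. On these data alone, how an amine or a carboxylic acid would read on this carbon also remains open.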